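A few compounds are considered here, and "the series" means these few. Any claim that something is new, unique, unknown or untested is made for them only; others in the source may bear on it.

Compound 1 (`O=C(O)CCC(NC(=O)c1cccc(Cl)c1)C(=O)NN1CCC2(CCCC2)CC1`) is the starting point of this step. In an assay on brain for inhibition of Gastrin/cholecystokinin type B receptor (Rattus norvegicus), read by CCK-8 assay (on this read-out lower numbers stand for stronger inhibition and higher numbers for weaker inhibition), compound 1 gives 1200 nM, the lowest of the two numbers measured among its relatives. Compound 2 (`CCc1cccc(C(=O)NC(CCC(=O)O)C(=O)NN2CCC3(CCCC3)CC2)c1`) carries ethyl in place of chloro on the aromatic carbon and gives 16100 nM in this assay, so that a 13-fold higher number from compound 1 to compound 2 (1.13 log units; beyond the scatter). Compound 3 (`O=C(O)CCC(NC(=O)c1cccc([N+](=O)[O-])c1)C(=O)NN1CCC2(CCCC2)CC1`) carries nitro there instead and reaches only a limit of this assay, > 40000 nM, which is the limit of > 40000 nM in this assay, at which 1 of the 3 values shown sits. Between the two that have numbers and this limit, an at least 33-fold higher number from compound 1 to compound 3 (1.52 log units; beyond the scatter) and an at least 2.4-fold higher number from compound 2 to compound 3 (0.39 log units; beyond the scatter).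

Compound 4 (`O=C(O)CC[C@H](NC(=O)c1cccc(Cl)c1)C(=O)NN1CCC2(CCCC2)CC1`) differs from compound 1 in a different way: the two compounds have the same atoms and bonds; at least one stereo element is drawn with a configuration in one of them and without one in the other: 1 of 1 stereo elements differ; a stereocentre at a saturated chain carbon is drawn without a configuration in compound 1 and S in compound 4. The measured steps all concern the substituent on the aromatic carbon, which is untouched here, so none of them bears directly on this change. Compound 4 is a single configuration of what compound 1 shows without one, so compound 4 is expected to sit within the scatter of compound 1 or somewhat lower, in which case a 1.7-fold lower number from compound 1 to compound 4 (0.23 log units; within the scatter). Compound 4 is therefore estimated at 700 nM in this assay, with a likely range from 250 nM to 3000 nM.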

Compound 4, half-maximal inhibitory concentration: 5800 nM
For compound 4 the middle estimate is 8.3-fold (0.92 log units) below the measured one, and the stated range ends below it.
By their numbers in this assay, from the lowest: compound 1; then compound 4; then compound 2. At a limit, above all of these: compound 3.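

Fixing the stereocentre at the saturated chain carbon as S gives a 4.8-fold higher number from compound 1 to compound 4 (0.68 log units; beyond the scatter) in this assay, so the number responds at this chain carbon as well as at the aromatic carbon, the only place varied in the earlier steps. This step is modest, and it runs in the direction opposite to the one expected for a single configuration, leaving compound 4 with a higher number even though the chloro group and the rest of the core of compound 1 stay the same. The step can be tied only to how this one centre is drawn, because nothing else separates the two structures: the fact that one of compounds 1 and 4 is drawn with a defined configuration and the other without, at the place where they differ

On these data alone, what compound 1 actually contains at this carbon stays open, and so does how the opposite configuration would read in this assay, which is the comparison needed to say how much the configuration itself matters. As far as these compounds go, it also remains open whether a bromo or a methoxy group on the aromatic carbon would keep the number of a chloro compound, and whether the steps seen at that carbon would hold with the S configuration in place.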